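Cyano for tert-butyl in a two-compound series

The source may hold more compounds than are shown below. What is called first, only, known or untested is meant among the compounds shown, and "the series" means these compounds.

- compound 1 `Cc1cc(=O)oc2cc(OCC(=O)c3ccc(C(C)(C)C)cc3)ccc12` at 22300 nM
- compound 2 `Cc1cc(=O)oc2cc(OCC(=O)c3ccccc3C(F)(F)F)ccc12` at 20400 nM

Both numbers come from a functional assay on CWR22R cells (Homo sapiens) for antiproliferative activity, with a stated time of 96 h (on this read-out higher numbers stand for weaker inhibition and lower numbers for stronger inhibition), and lie within the usual scatter of each other, so compound 1 shares its place on this scale with compound 2 and neither ranks ahead.

The next compound to be read is compound 3 `Cc1cc(=O)oc2cc(OCC(=O)c3ccc(C#N)cc3)ccc12` with the core of compound 1 unchanged. It carries cyano in place of tert-butyl on an aromatic carbon, para to a large group. The counted change is cyano in place of tert-butyl on an aromatic carbon and nothing else in the structure differs.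

Going by the values given here, no measured step isolates a single change. Among the compounds with values here, the only guide is how close compound 1 at 22300 nM and compound 2 at 20400 nM lie despite their different substituents. On that thin basis, no clear direction is expected. The expected step of a 1.1-fold lower number from compound 1 to compound 3 (0.05 log units; within the scatter) is estimated to stay within the scatter of this read-out. Compound 3 is estimated at 20000 nM with an expected range from 8000 nM to 45000 nM as the working figure.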

Compound 3, half-maximal inhibitory concentration: > 100000 nM
Compound 3 ended at the assay's limit; the forecaster's own chance of this, stated with the estimate: 15%; at least 5.0-fold (0.69 log units) between middle value and limit.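

In this assay compound 3 gives > 100000 nM, which is a limit of the assay and not a number: the limit of > 100000 nM in this assay, at which 1 of the 3 values shown sits.

Going by these compounds alone, exchanging tert-butyl for cyano on this aromatic carbon, para to a large group, is the first single change that can be read, and it gives an at least 4.4-fold higher number from compound 1 to compound 3 (0.65 log units; beyond the scatter), so the position does not tolerate every group alike on this read-out. The step is a lower bound only, and how far compound 3 lies past the limit stays unread.

The step changes two counted features together: cyano brings fewer heavy atoms than tert-butyl and also a hydrogen-bond acceptor, and a single pair cannot tell which of the two goes with the higher number, if either does. A methyl group on the same aromatic carbon would carry a small group with no hydrogen-bond acceptor, while a methoxy group or an amine would show how other heteroatom-bearing groups read at this position against compound 1.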